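This account rests on a few compounds, and the source may have more. Where it says the series, first, only, none or still open, it means among the compounds named here.

Measured compounds:
Compound 1 `CC(C)(C)c1ccc(CN2C(=O)S/C(=C\c3ccc(N)cc3)C2=O)cc1` gives 80000 nM in a functional assay on FM3A cells (Mus musculus) for cytotoxicity, read by cell counting, with a stated time of 2 days; on this read-out higher numbers stand for weaker inhibition and lower numbers for stronger inhibition.
Compound 2 `CC(C)(C)c1ccc(CN2C(=O)S/C(=C\c3cccc(N)c3)C2=O)cc1` gives 188000 nM in this assay.
Compound 3 `C=C(Br)C(=O)Nc1ccc(/C=C2\SC(=O)N(C)C2=O)cc1` gives 750 nM in this assay.

Compound 1 stands second highest of the three numbers. Its nearest neighbour is compound 2, reached by a 2.4-fold higher number from compound 1 to compound 2 (0.37 log units; beyond the scatter), a modest step beyond the scatter. For the measured compounds named here, compound 3 lies furthest away; its value in this assay is far lower than that of compound 1, but the two structures differ in several places at once, so no single step links them.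

Compound 4 `Nc1ccc(/C=C2\SC(=O)N(Cc3ccc(C(F)(F)F)cc3)C2=O)cc1` has not yet been measured. It differs from compound 1 by trifluoromethyl in place of tert-butyl on an aromatic carbon, on an aromatic carbon of a six-membered aromatic ring of carbon only, para to a large group. Going by the values given here, none of the measured steps touches this part of the core: the one step available, from compound 1 to compound 2, moves the amino group and not the substituent on the benzyl ring, so it bears only loosely on the change. Without a comparable step, no change beyond the scatter is expected in this assay, and compound 4 is estimated near compound 1, so that no change at the digits printed from compound 1 to compound 4 (within the scatter) is expected to stay small. Compound 4 is therefore estimated at 80000 nM, in a range from 30000 nM to 200000 nM.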

Compound 4, half-maximal inhibitory concentration: 134000 nM
Compound 4: the middle estimate sits 1.7-fold (0.22 log units) below what was measured; the range from low to high includes it.
By their numbers in this assay, from the lowest: compound 3; then compounds 1, 4 and 2 (each within the scatter of the next, the first and the last beyond it).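

In this assay, for the compounds shown here, the one exchange at this position, trifluoromethyl in place of tert-butyl on an aromatic carbon para to a large group, comes with a 1.7-fold higher number from compound 1 to compound 4 (0.22 log units; within the scatter) and so cannot be told apart from repeat measurement. Going by these compounds alone, this is the first reading at this place, as the earlier step of a 2.4-fold higher number from compound 1 to compound 2 (0.37 log units; beyond the scatter) concerned only the amino group, and it shows that these two groups, each of 4 heavy atoms, read alike on the core of compound 1. Nothing at hand accounts for this result.

On these data alone, it remains open whether a carboxylic acid or a nitrile at the same aromatic carbon would give a number beyond the scatter from that of compound 1. The compounds shown also leave open whether trifluoromethyl reads the same when paired with the 3-aminophenyl of compound 2.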